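Three Sulfonamides Measured, a Fourth Awaiting Its Number

The compounds below may be only part of what the source reports. "The series", "measured", "known", "first", "only" and "open" are said of these compounds alone.

Compound 1 `CC(C)(C)c1ccc(CNCCCNS(=O)(=O)c2cc(C(F)(F)F)cc(C(F)(F)F)c2)cc1` belongs to a small set of sulfonamides sharing one core and differing only in the group on a saturated chain carbon bound to an amine nitrogen. In a functional assay on BE(2)-C cells (Homo sapiens) for inhibition, read by MTT assay, with a stated time of 72 h (on this read-out lower numbers stand for stronger inhibition of growth and higher numbers for weaker inhibition of growth), compound 1 gives 2500 nM. Among the three numbers measured so far it stands second highest: its nearest neighbour is compound 3 `O=S(=O)(NCCCNCC1COc2ccccc2O1)c1cc(C(F)(F)F)cc(C(F)(F)F)c1`, which in this assay gives 2800 nM, and its furthest is compound 2 `O=S(=O)(NCCCCNCc1ccc(Br)cc1)c1cc(C(F)(F)F)cc(C(F)(F)F)c1`, which gives 2200 nM. All three lie within the scatter of one another, so no order among them can be read.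

Compound 4 `COc1ccccc1CNCCCNS(=O)(=O)c1cc(C(F)(F)F)cc(C(F)(F)F)c1` has not been measured. It differs from compound 1 in one place: 2-methoxyphenyl in place of 4-(tert-butyl)phenyl on a saturated chain carbon bound to an amine nitrogen. Among the compounds with values here, the only measured step that touches the same place is a 1.1-fold higher number from compound 1 to compound 3 (0.05 log units; within the scatter), and it stayed within the scatter. The change to the chain in compound 2 likewise left the number close to that of compound 1. With nothing in the measured steps pointing in either direction, no movement beyond the scatter is expected from compound 1 to compound 4, and the step is estimated as a 1.0-fold higher number from compound 1 to compound 4 (0.02 log units; within the scatter). Compound 4 is therefore expected to give about 2600 nM, within a range from 1300 nM to 5200 nM.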

Compound 4, concentration for 50% growth inhibition: 3600 nM
Compound 4: the middle estimate sits 1.4-fold (0.14 log units) below what was measured; low and high end bracket the measured number.
By their numbers in this assay, from the lowest: compounds 2, 1, 3 and 4 (each within the scatter of the next).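

With 2-methoxyphenyl, this position has now taken a third group without the number leaving the scatter: in this assay the exchange for 4-(tert-butyl)phenyl gives a 1.4-fold higher number from compound 1 to compound 4 (0.16 log units; within the scatter) and the exchange for 2,3-dihydro-1,4-benzodioxin-2-yl gives a 1.3-fold higher number from compound 3 to compound 4 (0.11 log units; within the scatter) in the same read-out. The change from 4-(tert-butyl)phenyl also brings in an oxygen and a hydrogen-bond acceptor and takes out two heavy atoms, and even the wider change in the chain and the group together, which gives a 1.6-fold higher number from compound 2 to compound 4 (0.21 log units; within the scatter) on this read-out, stays within the scatter. So at this level of growth inhibition, the measured compounds show no difference among these groups, and no measurement available here bears on why the number holds.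

From the compounds shown here alone, whether a carboxylic acid or a dimethylamino group on the phenyl ring would move the number beyond the scatter remains open. All four compounds also carry the same trifluoromethyl groups on the sulfonamide side, so what a nitrile or a methoxy group would do there is equally unknown.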